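This account rests on a few compounds, and the source may have more. Where it says the series, first, only, none or still open, it means among the compounds named here.

Among the measured compounds shown here, in a functional assay on A549 cells (Homo sapiens) for antiproliferative activity, read by MTT assay, with a stated time of 72 h (a lower number here means a stronger inhibitor, a higher number a weaker inhibitor), compound 2 `COc1ncc(-c2ccc3c(c2)N(C2CCCCC2)C(=O)CO3)cc1NS(=O)(=O)c1ccc(F)cc1` gives 24600 nM, the higher of the two numbers measured so far, while compound 1 `COc1cccc(N2C(=O)COc3ccc(-c4cnc(OC)c(NS(=O)(=O)c5ccc(F)cc5)c4)cc32)c1` gives 11200 nM. Compound 3 `COc1ncc(-c2ccc3c(c2)N(c2ccccc2)C(=O)CO3)cc1NS(=O)(=O)c1ccc(F)cc1` keeps the core of compound 2 and differs only in the group on the amide-type nitrogen in a ring: phenyl in place of cyclohexyl on an amide-type nitrogen in a ring. For the measured compounds named here, one measured step bears on this change: a 2.2-fold higher number from compound 1 to compound 2 (0.34 log units; beyond the scatter), modest but beyond the scatter, with cyclohexyl in place of 3-methoxyphenyl at that same nitrogen. Going by the values given here, compound 3 restores an aromatic ring there, but as phenyl rather than 3-methoxyphenyl, and no measured compound separates those two groups. On the strength of a 2.2-fold higher number from compound 1 to compound 2 (0.34 log units; beyond the scatter), a step of similar size is expected in the opposite direction, towards a lower number in this assay. The expected change is a 1.9-fold lower number from compound 2 to compound 3 (0.28 log units; within the scatter). Compound 3 is estimated at 13000 nM, with an expected range from 6000 nM to 26000 nM.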

Compound 3, half-maximal inhibitory concentration: 3490 nM
The estimate for compound 3 lay 3.7-fold (0.57 log units) above the measured number, outside the stated range (below it).
By their numbers in this assay, from the lowest: compound 3; then compound 1; then compound 2.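

In this assay, among the compounds shown here, the ring on the amide-type nitrogen counts for more than the earlier pair showed: both groups have the same count of six carbons, yet phenyl in place of cyclohexyl gives a 7.0-fold lower number from compound 2 to compound 3 (0.85 log units; beyond the scatter), the largest step so far. The earlier compounds could not separate phenyl from 3-methoxyphenyl, and hydrogen in place of methoxy on that aromatic ring now gives a 3.2-fold lower number from compound 1 to compound 3 (0.51 log units; beyond the scatter), so the methoxy group is not needed for the lowest number among these three compounds. Nothing here accounts for either step.

From the compounds shown here alone, it remains open whether a phenyl ring carrying fluorine or a hydroxyl group, or a small chain such as methyl on that nitrogen, would fall above or below compound 3. Going by these compounds, whether this order holds in other cell lines also remains open.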